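The source may hold more compounds than are shown below. What is called first, only, known or untested is meant among the compounds shown, and "the series" means these compounds.

Of the compounds shown here, three that share one core have been tested in a functional assay on MCF7 cells (Homo sapiens) for inhibition, read by MTT assay, with a stated time of 72 h (a lower number here means a stronger inhibitor, a higher number a weaker inhibitor), and they differ in a single substituent on an aromatic ring. Compound 1 `COc1cc2c(Oc3ccc(NC(=O)c4nn(-c5ccccc5C)cc(C)c4=O)cc3F)ccnc2cc1OCCCC(=O)NO` gives 2600 nM, compound 2 `COc1cc2c(Oc3ccc(NC(=O)c4nn(-c5ccccc5)cc(C)c4=O)cc3F)ccnc2cc1OCCCC(=O)NO` gives 1900 nM, and compound 3 `COc1cc2c(Oc3ccc(NC(=O)c4nn(-c5ccccc5F)cc(C)c4=O)cc3F)ccnc2cc1OCCCC(=O)NO` gives 2100 nM. Compound 3 therefore stands level with the other two, with no real separation among the three. The measured steps are a 1.4-fold lower number from compound 1 to compound 2 (0.14 log units; within the scatter), a 1.2-fold lower number from compound 1 to compound 3 (0.09 log units; within the scatter) and a 1.1-fold higher number from compound 2 to compound 3 (0.04 log units; within the scatter).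

Compound 4 `COc1cc2c(Oc3ccc(NC(=O)c4nn(-c5ccccc5F)cc(C)c4=O)cc3)ccnc2cc1OCCCC(=O)NO` keeps the substituent of compound 3 and changes the molecule elsewhere: hydrogen in place of fluoro on an aromatic carbon. In words, this is hydrogen in place of fluoro on an aromatic carbon, ortho to a large group and meta to a large group. Going by the values given here, no measured pair tests this carbon, so the evidence is indirect. The nearest guide is the exchange of the same two atoms at another place, a 1.1-fold higher number from compound 2 to compound 3 (0.04 log units; within the scatter), which is very small. The other steps, a 1.4-fold lower number from compound 1 to compound 2 (0.14 log units; within the scatter) and a 1.2-fold lower number from compound 1 to compound 3 (0.09 log units; within the scatter), are also small. In this assay, no step beyond the scatter is therefore expected, and the estimated step is a 1.1-fold lower number from compound 3 to compound 4 (0.04 log units; within the scatter). For compound 4 the estimated value is 1900 nM, with an expected range from 900 nM to 4000 nM.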

Compound 4, half-maximal inhibitory concentration: 2650 nM
Estimate against measurement, compound 4: 1.4-fold (0.14 log units) below; measured number inside the range.
By their numbers in this assay, from the lowest: compounds 2, 3, 1 and 4 (each within the scatter of the next).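

Taking the fluoro off this carbon, ortho to a large group and meta to a large group, gives a 1.3-fold higher number from compound 3 to compound 4 (0.10 log units; within the scatter) in this assay and so provides the first direct reading at this position, where the earlier steps could only offer a guide from another place. Going by these compounds alone, in this pair, hydrogen and fluoro cannot be told apart on this carbon, just as hydrogen and fluoro could not be told apart at the place varied among compounds 1 to 3, so the first change at a second place in the molecule also leaves the number within the scatter. Nothing available here speaks to what lies behind this small step.

From the compounds shown here alone, the pair compares only fluoro and hydrogen, two small substituents, so how a methoxy group, an amine or a carboxylic acid on this carbon would read in this assay remains open. Every step among these four compounds lies within the scatter, which also leaves open whether any change at either of these two places can move the number beyond it.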